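This account rests on a few compounds, and the source may have more. Where it says the series, first, only, none or still open, it means among the compounds named here.

Working notes on the series in a functional assay on HCC827 cells (Homo sapiens) for antiproliferative activity, read by CCK-8 assay, with a stated time of 72 h; a higher number here means a weaker inhibitor, a lower number a stronger inhibitor. Of the compounds shown here, two have been measured so far. Compound 1 `C#Cc1cccc(Nc2ncnc3cc(OCCOC(=O)c4ccccc4OC(C)=O)c(OCCOC(=O)c4ccccc4OC(C)=O)cc23)c1` gives 900 nM, and compound 2 `C#Cc1cccc(Nc2ncnc3cc(OCCOC)c(OCCOC(=O)c4ccccc4OC(C)=O)cc23)c1` gives 100 nM, the lower of the two numbers. Compound 2 therefore stands at the low end of this short series.

Compound 3 `C#Cc1cccc(Nc2ncnc3cc(OCCOC)c(OCCOC(=O)C(C)c4ccc(CC(C)C)cc4)cc23)c1` keeps the methyl-capped chain of compound 2 and alters the remaining ester: 1-(4-isobutylphenyl)ethyl in place of 2-acetoxyphenyl on a carbonyl carbon. In words, this is 1-(4-isobutylphenyl)ethyl in place of 2-acetoxyphenyl on a carbonyl carbon.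

For the measured compounds named here, only one measured step bears on this change, and only indirectly. With methyl in place of (2-acetoxyphenyl)carbonyl on an oxygen on a saturated carbon, the series shows a 9.0-fold lower number from compound 1 to compound 2 (0.95 log units; beyond the scatter). That modest step shows that the number can move beyond the scatter when these chains change, but it does not test the incoming group. No step beyond the scatter is therefore expected in this assay, and the data favour neither direction, so the range stays wide.

The expected change is a 1.3-fold higher number from compound 2 to compound 3 (0.11 log units; within the scatter). For compound 3 the estimated value is 130 nM, with an expected range from 35 nM to 500 nM.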

Compound 3, half-maximal inhibitory concentration: > 10000 nM
Compound 3: no number, only a limit (the forecaster's own chance of this, stated with the estimate: 3%); middle value at least 76-fold (1.88 log units) from the limit.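

In this assay, going by these compounds, compound 3 reads > 10000 nM, which is a limit of the assay and not a number, so the true value stays unknown and the step below is a lower bound: the limit of > 10000 nM in this assay, at which 1 of the 3 values shown sits.

Replacing 2-acetoxyphenyl with 1-(4-isobutylphenyl)ethyl on a carbonyl carbon, with the methyl-capped chain held fixed, gives an at least 100-fold higher number from compound 2 to compound 3 (2.00 log units; beyond the scatter), which shows that the group on this ester carbonyl is far from indifferent in this series. For the compounds shown here, the earlier step, a 9.0-fold lower number from compound 1 to compound 2 (0.95 log units; beyond the scatter), concerned only the other chain, so this is the first measured evidence that a change on the remaining ester alone can take the number beyond the scatter.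

The single change swaps the whole group, so the compounds shown do not separate the contribution of the isobutyl group, the methyl on the carbon attached to the carbonyl, or the departure of the acetoxy group. On these data alone, how a plain phenyl, a 2-hydroxyphenyl or a short alkyl chain on this carbonyl would read, or an amide in place of the ester, remains open.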